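The compounds below may be only part of what the source reports. "The series", "measured", "known", "first", "only" and "open" are said of these compounds alone.

Measured so far in a functional assay on MCF7 cells (Homo sapiens) for cytotoxicity, read by MTT assay, with a stated time of 72 h; a higher number here means that more compound is tolerated, a lower number that less compound is tolerated:
- compound 1, `CSc1ccc(CNc2nc(SC)nc3ncccc23)cc1`: 9130 nM
- compound 2, `COc1ccc(CNc2nc(SC)nc3ncccc23)cc1`: recorded only as a limit, > 100000 nM
- compound 3, `CSc1nc(NCCCCCO)c2cccnc2n1`: recorded only as a limit, > 100000 nM

Where compound 3 stands: it sits at the limit of > 100000 nM in this assay, at which 2 of the 3 values shown sit, so no number is known for it, only that it is at the limit. Going by the values given here, the one quantified step is an at least 10-fold higher number from compound 1 to compound 2 (1.03 log units; beyond the scatter). That step concerns a substituent on the phenyl ring and not the change now in question, so it does not bear directly on the step to compound 4.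

Compound 4 is `CSc1nc(NCc2ccccc2)c2cccnc2n1`. The change from compound 3 is phenyl in place of 4-hydroxybutyl on a saturated chain carbon bound to a nitrogen on an aromatic ring. As far as these compounds go, it gives the unsubstituted counterpart of the phenyl ring that in compound 1 carries methylsulfanyl and in compound 2 carries methoxy; the two measured values there span the range from a number to the limit, so for an unsubstituted phenyl both outcomes remain open.

Expectation: the step of an at least 2.5-fold lower number from compound 3 to compound 4 (0.39 log units; beyond the scatter) is estimated as a move from the limit toward a measurable number, but with a fair chance that compound 4 also reports only a limit. For compound 4 the estimate in this assay is 40000 nM, with a range from 8000 nM to 100000 nM.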

Compound 4, concentration lethal to 50% of the cells: > 100000 nM
Compound 4 gave a limit, no number; the forecaster's own chance of this, stated with the estimate: 50%; middle value at least 2.5-fold (0.39 log units) from the limit.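

Compound 4 is recorded only as a limit, so the unsubstituted phenyl ring gives no number and joins the shared limit: the limit of > 100000 nM in this assay, at which 3 of the 4 values shown sit.

In this assay, hydrogen in place of methylsulfanyl on an aromatic carbon gives an at least 10-fold higher number from compound 1 to compound 4 (1.03 log units; beyond the scatter), which shows that compound 1 owes its measurable number to the methylsulfanyl group on the phenyl ring, and not to the phenyl ring alone. Phenyl in place of 4-hydroxybutyl does not by itself bring a number into reach, and the steps to compound 4 from compound 2 and from compound 3 cannot be read, since both ends of each are limits.

As far as these compounds go, how far compounds 2, 3 and 4 lie from one another remains unknown, and so does whether the number seen for compound 1 is specific to methylsulfanyl or would also appear with ethylsulfanyl or a chlorine atom on the phenyl ring. Also open, from the compounds shown here alone, is whether an amine or a carboxylic acid in place of the hydroxy group of compound 3 would leave the limit.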